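A Second Methyl Group in a Cell Growth Series

This account rests on a few compounds, and the source may have more. Where it says the series, first, only, none or still open, it means among the compounds named here.

Compound 1 `Cc1ccccc1NS(=O)(=O)c1ccc(N2CCNC2=O)cc1`: 150 nM
Compound 2 `O=C1NCCN1c1ccc(S(=O)(=O)Nc2ccc(C3CCCCC3)cc2)cc1`: > 1000 nM
Compound 3 `CC(C)(C)c1ccc(NS(=O)(=O)c2ccc(N3CCNC3=O)cc2)cc1`: > 1000 nM

Among the measured compounds shown here, in a functional assay on M21 cells (Homo sapiens) for antiproliferative activity, read by sulforhodamine B assay, with a stated time of 48 h (a higher number here means a weaker inhibitor, a lower number a stronger inhibitor), compound 1 gives 150 nM, the only full number among the three. Compound 2 reaches only a limit of the assay, > 1000 nM. Compound 3 likewise stops at a limit, > 1000 nM. The step that the two limits leave unreadable from compound 2 to compound 3 therefore cannot be read, because both values sit at the limit of > 1000 nM in this assay, at which 2 of the 3 values shown sit.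

Compound 4 `Cc1ccc(NS(=O)(=O)c2ccc(N3CCNC3=O)cc2)c(C)c1` differs from compound 1 by methyl in place of hydrogen on an aromatic carbon. For the measured compounds named here, no measured step bears on this change; compounds 2 and 3 carry different, larger groups and give only limits. A small methyl addition is expected to move the number no further than the scatter. Compound 4 is estimated at 200 nM, from 80 nM to 600 nM. The expected step is a 1.3-fold higher number from compound 1 to compound 4 (0.12 log units; within the scatter).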

Compound 4, half-maximal inhibitory concentration: 150 nM
The estimate for compound 4 lay 1.3-fold (0.12 log units) above the measured number; the measured number falls inside the stated range.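

Changing the 2-methylphenyl to the 2,4-dimethylphenyl gives no change at the digits printed from compound 1 to compound 4 (within the scatter) in this assay. Among the compounds shown here, this aromatic carbon, para to a large group, can therefore carry a methyl group with the number unmoved, a reading that the earlier compounds did not give. Nothing measured here offers an explanation for this outcome.

Going by these compounds, whether an amine, a carboxylic acid or a longer chain on this carbon would also leave the number unmoved remains open. The role of the methyl group already present in compound 1 is also open, since no compound shown differs from it only by losing that group.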